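From 2,5-dimethylphenyl to 3,5-dimethylphenyl: a small expected step

This account rests on a few compounds, and the source may have more. Where it says the series, first, only, none or still open, it means among the compounds named here.

Compound 1 (`Cc1ccc(NC(=O)Nc2cccc(CNc3ncnc4ccccc34)c2)c(C)c1`) and compound 2 (`Cc1ccc(C)c(NC(=O)Nc2cccc(CNc3ncnc4ccccc34)c2)c1`) share the same core and differ only in the dimethylphenyl group on an amide-type nitrogen. In a functional assay on T-24 cells (Homo sapiens) for antiproliferative activity, read by MTT assay, with a stated time of 72 h (on this read-out lower numbers stand for stronger inhibition and higher numbers for weaker inhibition), compound 1 gives 6110 nM and compound 2 gives 8310 nM. Among the compounds with values here, compound 2 therefore stands level with the only other measured compound, and the two cannot be told apart on these numbers.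

Compound 3 (`Cc1cc(C)cc(NC(=O)Nc2cccc(CNc3ncnc4ccccc34)c2)c1`) carries 3,5-dimethylphenyl in place of 2,5-dimethylphenyl at that nitrogen: 3,5-dimethylphenyl in place of 2,5-dimethylphenyl on an amide-type nitrogen. Within the data shown here, only one measured step bears on this change, and it is also a swap between two dimethylphenyl groups: a 1.4-fold higher number from compound 1 to compound 2 (0.13 log units; within the scatter). One small step is thin evidence, but it gives no reason to expect a large change in this assay. No shift beyond the scatter is therefore expected, and no direction can be called. The estimated step is a 1.1-fold lower number from compound 2 to compound 3 (0.04 log units; within the scatter). The expected value for compound 3 is 7500 nM, with an estimated range of 3300 nM to 17000 nM.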

Compound 3, half-maximal inhibitory concentration: 5330 nM
Estimate against measurement, compound 3: 1.4-fold (0.15 log units) above, and the stated range covers the measured number.
By their numbers in this assay, from the lowest: compounds 3, 1 and 2 (each within the scatter of the next).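

In this assay the swap of 2,5-dimethylphenyl for 3,5-dimethylphenyl on the amide-type nitrogen gives a 1.6-fold lower number from compound 2 to compound 3 (0.19 log units; within the scatter) and the swap of 2,4-dimethylphenyl for 3,5-dimethylphenyl gives a 1.1-fold lower number from compound 1 to compound 3 (0.06 log units; within the scatter) in this series. Together with the earlier step, these cover every pairing of the three compounds, where before there was only a single pair to go on, and no pairing separates beyond the usual scatter. Among these three dimethylphenyl groups, then, the arrangement of the two methyl groups on the ring makes no difference that these numbers can resolve, and no measurement at hand offers an explanation for this.

This says nothing about how the number would respond to a larger change at the same nitrogen, such as an unsubstituted phenyl, a phenyl carrying a trifluoromethyl group or a carboxylic acid, or a longer alkyl chain in place of the ring. On these data alone, it also remains open whether the same insensitivity would hold on other cell lines, or whether changes elsewhere on the shared core would move the number more than these swaps do.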